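The compounds below may be only part of what the source reports. "The series", "measured", "known", "first", "only" and "open" are said of these compounds alone.

Compound 1 `COc1cccc(-c2cccc(COc3ccc(OCC(=O)O)c(F)c3)c2)c1` gives 540 nM in a functional assay on CHO cells for agonist activity at Free fatty acid receptor 1 (Homo sapiens), read by FLIPR and calcium flux; a lower number here means that less compound is needed, a higher number that more compound is needed for the effect. Compound 3 `O=C(O)COc1ccc(OCc2cccc(-c3ccc(OCC4CC4)cc3)c2)cc1F` gives 540 nM in this assay, no change from compound 1 at the digits shown, and compound 2 `O=C(O)COc1ccc(OCc2cccc(-c3cccc(OCC4CC4)c3)c2)cc1F` gives 670 nM, with a 1.2-fold higher number from compound 1 to compound 2 (0.09 log units; within the scatter). All three values lie within the scatter of one another, so compound 1 sits neither apart from nor clearly below its neighbours.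

Compound 4 `O=C(O)COc1ccc(OCc2cccc(-c3ccc4ncoc4c3)c2)cc1F` differs from compound 1 by 1,3-benzoxazol-6-yl in place of 3-methoxyphenyl on an aromatic carbon. Among the measured compounds shown here, no measured step alters this part of the molecule; the single measured step, a 1.2-fold higher number from compound 1 to compound 2 (0.09 log units; within the scatter), concerns another group and stays within the scatter, and compounds 2 and 3 likewise differ only within the scatter. The data therefore give no ground for a shift beyond the scatter. Compound 4 is expected at 540 nM, range 270 nM to 1100 nM, an expected step of no change at the digits printed from compound 1 to compound 4 (within the scatter).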

Compound 4, half-maximal effective concentration: 3240 nM
Compound 4: middle estimate off by 6.0-fold (0.78 log units), on the low side; the measured number lies above the stated range.
By their numbers in this assay, from the lowest: compounds 1, 3 and 2 (each within the scatter of the next); then compound 4.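

Among the compounds shown here, this aromatic carbon is sensitive to the group it carries: in this assay, 1,3-benzoxazol-6-yl in place of 3-methoxyphenyl gives a 6.0-fold higher number from compound 1 to compound 4 (0.78 log units; beyond the scatter), the first step beyond the scatter. The earlier step, a 1.2-fold higher number from compound 1 to compound 2 (0.09 log units; within the scatter), left 3-methoxyphenyl's phenyl ring in place and did not reveal this sensitivity. No evidence here bears on the cause of the new step.

On these data alone, it remains open whether the five-membered aromatic ring, its nitrogen or the loss of the methoxy group accounts for the step. As far as these compounds go, how a phenyl ring carrying an amine or a carboxylic acid would read at this carbon also remains open.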